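The source may hold more compounds than are shown below. What is called first, only, known or untested is meant among the compounds shown, and "the series" means these compounds.

In a physicochemical assay, read by spectrophotometry, with a stated time of 30 min (on this read-out lower numbers stand for stronger inhibition and higher numbers for weaker inhibition), compound 1 `O=[N+]([O-])c1ccc(Cn2cc(COc3ccccc3)nn2)cc1` gives 10.1 ug/mL and compound 2 `O=[N+]([O-])c1ccc(Cn2cc(COc3cccc([N+](=O)[O-])c3)nn2)cc1` gives 17.1 ug/mL, so the two values lie within the scatter of each other. Compound 3 `O=[N+]([O-])c1cccc(OCc2cn(Cc3ccc(Br)cc3)nn2)c1` differs from compound 2 by bromo in place of nitro on an aromatic carbon, with bromo in place of nitro on an aromatic carbon, para to a large group. Among the compounds with values here, the only measured step, a 1.7-fold higher number from compound 1 to compound 2 (0.23 log units; within the scatter), is nitro in place of hydrogen elsewhere in the structure and bears only indirectly, since no measurement yet covers this change. No shift beyond the scatter is therefore expected in this assay. The expected step is a 1.2-fold lower number from compound 2 to compound 3 (0.09 log units; within the scatter). For compound 3 the estimated value is 14 ug/mL, with an expected range of 6 ug/mL to 32 ug/mL.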

Compound 3, half-maximal inhibitory concentration: 29.4 ug/mL
Compound 3: middle estimate off by 2.1-fold (0.32 log units), on the low side, and the stated range covers the measured number.
By their numbers in this assay, from the lowest: compounds 1, 2 and 3 (each within the scatter of the next, the first and the last beyond it).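

In this assay bromo in place of nitro at this position, on an aromatic carbon para to a large group, gives a 1.7-fold higher number from compound 2 to compound 3 (0.24 log units; within the scatter) and so stays within the scatter. Within the data shown here, this is the first reading at this position, since the earlier step lay elsewhere in the structure, and it shows that these two groups cannot be told apart here. No supporting data bear on this result.

From the compounds shown here alone, whether an amine or a carboxylic acid at this position would give a step beyond the scatter remains open. Going by these compounds, whether the same holds on a different shared core also remains open.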